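From 2-hydroxyphenyl to 2,6-dichlorophenyl on the shared core

This account rests on a few compounds, and the source may have more. Where it says the series, first, only, none or still open, it means among the compounds named here.

Measured so far in a functional assay on QG-56 cells (Homo sapiens) for cytotoxicity, read by MTT assay, with a stated time of 48 h; on this read-out higher numbers stand for weaker inhibition and lower numbers for stronger inhibition:
Compound 1 `COc1cc(/C=C/C(=O)C2=C(/C=C/c3ccc(O)c(OC)c3)NC(=S)NC2c2ccc(C)cc2)ccc1O`: 12500 nM
Compound 2 `COc1cc(/C=C/C(=O)C2=C(/C=C/c3ccc(O)c(OC)c3)NC(=S)NC2c2ccccc2O)ccc1O`: 50000 nM

For the measured compounds named here, of these two numbers, the one for compound 2 is the higher, and the only neighbour is compound 1 at 12500 nM. Compound 3 `COc1cc(/C=C/C(=O)C2=C(/C=C/c3ccc(O)c(OC)c3)NC(=S)NC2c2c(Cl)cccc2Cl)ccc1O` has not yet been measured. It differs from compound 2 in one place: 2,6-dichlorophenyl in place of 2-hydroxyphenyl on a saturated ring carbon. In words, 2,6-dichlorophenyl stands in place of 2-hydroxyphenyl on a saturated ring carbon.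

Going by the values given here, only one measured step bears on this change. It is a 4.0-fold higher number from compound 1 to compound 2 (0.60 log units; beyond the scatter), a modest step beyond the scatter, in which 2-hydroxyphenyl took the place of 4-methylphenyl on a saturated ring carbon. Among the compounds with values here, no compound with 2,6-dichlorophenyl has been measured, and a single pair is thin evidence. Going by a 4.0-fold higher number from compound 1 to compound 2 (0.60 log units; beyond the scatter), leaving 2-hydroxyphenyl is expected to give a step of similar modest size toward a lower number in this assay. The expected change is a 3.3-fold lower number from compound 2 to compound 3 (0.52 log units; beyond the scatter). Compound 3 is estimated at 15000 nM, with an expected range of 4500 nM to 50000 nM.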

Compound 3, half-maximal inhibitory concentration: 100000 nM
For compound 3 the middle estimate is 6.7-fold (0.82 log units) below the measured one; measured number outside the range, above it.
By their numbers in this assay, from the lowest: compound 1; then compounds 2 and 3 (each within the scatter of the next).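

In this assay, exchanging 2-hydroxyphenyl for 2,6-dichlorophenyl gave a step within the scatter (a 2.0-fold higher number from compound 2 to compound 3 (0.30 log units; within the scatter)), so these two groups cannot be ranked at this saturated ring carbon, even though one has a hydrogen-bond donor and acceptor and the other has neither. Leaving 2-hydroxyphenyl therefore did not by itself bring the number closer to that of compound 1, as the 2,6-dichlorophenyl compound remains clearly separated from the 4-methylphenyl compound (an 8.0-fold higher number from compound 1 to compound 3 (0.90 log units; beyond the scatter)), and compound 1 is the most potent of the three in this assay. No measurement offered here accounts for this outcome.

The three compounds cannot show whether the advantage of compound 1 belongs to the methyl group or to its place on the phenyl ring, a question that 2-methylphenyl, 4-chlorophenyl and 4-hydroxyphenyl analogues on the shared core would address. From the compounds shown here alone, how this position responds to a phenyl ring bearing an amine or a carboxylic acid, or to a simple methyl group with no ring at all, also remains open.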